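The source may report more compounds than this note shows. Statements on the series, on what has been measured and on what is new or still open speak of the compounds shown alone.

Measured so far:
compound 1 `CN(C)C(=O)c1cccnc1NCCCN1CCN(c2ccccc2OCC2CC2)CC1`, in a functional assay on aorta for antagonist activity at Alpha-1D adrenergic receptor (Rattus norvegicus) (on this read-out lower numbers stand for tighter binding and higher numbers for weaker binding), 10 nM;
compound 2 `CCCc1ccccc1N1CCN(CCCNc2ncccc2C(=O)N(C)C)CC1`, in this assay 31.6 nM.

Among the compounds with values here, compound 2 holds the higher of the two numbers; the only measured step, a 3.2-fold higher number from compound 1 to compound 2 (0.50 log units; beyond the scatter), separates it from compound 1. Compound 3 `CN(C)C(=O)c1cccnc1NCCCN1CCN(c2ccccc2C(F)(F)F)CC1` differs from compound 2 by trifluoromethyl in place of propyl on an aromatic carbon, on an aromatic carbon of a six-membered aromatic ring of carbon only, ortho to a large group. Within the data shown here, no measured step involves trifluoromethyl; the one step at this position, a 3.2-fold higher number from compound 1 to compound 2 (0.50 log units; beyond the scatter), was modest. For compound 3 a step of similar size or none beyond the scatter is expected, a 1.3-fold higher number from compound 2 to compound 3 (0.10 log units; within the scatter). Compound 3 is estimated at 40 nM, range 13 nM to 130 nM.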

Compound 3, dissociation constant: 316 nM
Compound 3: middle estimate off by 7.9-fold (0.90 log units), on the low side; the measured number lies above the stated range.
By their numbers in this assay, from the lowest: compound 1; then compound 2; then compound 3.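

Within the data shown here, this aromatic carbon tolerates less change than the one earlier step suggested: in this assay trifluoromethyl in place of propyl gives a 10-fold higher number from compound 2 to compound 3 (1.00 log units; beyond the scatter) and trifluoromethyl in place of cyclopropylmethoxy gives a 32-fold higher number from compound 1 to compound 3 (1.50 log units; beyond the scatter) on the same core. Among these three compounds, trifluoromethyl therefore holds the highest number and cyclopropylmethoxy the lowest. No measured evidence is available to explain the size of these steps. Still open, going by these compounds, is how a methoxy group, an amine or a longer ether chain would rank at this carbon. On these data alone, whether trifluoromethyl behaves the same way with a different amide on the core also remains open.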